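Three Limits and an Azetidine Amide Variant

A few compounds are considered here, and "the series" means these few. Any claim that something is new, unique, unknown or untested is made for them only; others in the source may bear on it.

Compound 1 `O=C(/C=C/CNCCOc1ccc(Oc2c(-c3ccc(F)cc3)sc3cc(O)ccc23)cc1)N1CCCC1` — in a functional assay on MDA-MB-231 cells (Homo sapiens) for antiproliferative activity, read by CCK-8 assay, with a stated time of 48 h (a higher number here means a weaker inhibitor, a lower number a stronger inhibitor), compound 1 gives > 50000 nM, a limit of the assay.
Compound 2 `C=C(C)C(=O)NCCOc1ccc(Oc2c(-c3ccc(F)cc3)sc3cc(O)ccc23)cc1` — in this assay compound 2 gives > 50000 nM, a limit of the assay.
Compound 3 `O=C(CCCNCCOc1ccc(Oc2c(-c3ccc(F)cc3)sc3cc(O)ccc23)cc1)N1CCC1` — in this assay compound 3 gives > 50000 nM, a limit of the assay.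

Compound 3 therefore stands at the limit, and so do the other two measured compounds: the limit of > 50000 nM in this assay, at which 3 of the 3 values shown sit. The three single-site steps among them, a step that the two limits leave unreadable from compound 1 to compound 2, a step that the two limits leave unreadable from compound 1 to compound 3 and a step that the two limits leave unreadable from compound 2 to compound 3, cannot be sized, since both ends of each sit at the limit. None of them bears readably on the next change.

Compound 4 `C=C(C)C(=O)N1CC(Oc2ccc(Oc3c(-c4ccc(F)cc4)sc4cc(O)ccc34)cc2)C1` differs from compound 3 by 1-((1-methylethenyl)carbonyl)azetidin-3-yl in place of 2-((3-((azetidin-1-yl)carbonyl)propyl)amino)ethyl on an oxygen on an aromatic ring. Among the compounds with values here, with every measured value a limit, the direction of this change rests on no measured step. The step of an at least 1.6-fold lower number from compound 3 to compound 4 (0.22 log units; that floor lies within the scatter) is expected to be small or unreadable. Compound 4 is estimated at 30000 nM, within a range from 5000 nM to 100000 nM, with a fair chance that only a limit is reported.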

Compound 4, half-maximal inhibitory concentration: > 50000 nM
Compound 4 gave a limit, no number (the forecaster's own chance of this, stated with the estimate: 60%); middle value at least 1.6-fold (0.22 log units) away from the limit.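

Compound 4 sits at a limit of the assay, as do compound 2 and compound 3, so neither of its new steps can be read: the limit of > 50000 nM in this assay, at which 4 of the 4 values shown sit.

The compounds shown leave open which structural change, if any, would give a measurable number in this assay.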